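Nitrile to thiocarboxamide on a stomach-inhibition read-out

The source may report more compounds than this note shows. Statements on the series, on what has been measured and on what is new or still open speak of the compounds shown alone.

Measured compounds:
Compound 1, `N#CCCn1nc(-c2ccccc2)ccc1=O`: 10.1%
Compound 2, `N=C(S)CCN1N=C(c2cccs2)CCC1=O`: 58.5%
Compound 3, `O=c1cccnn1CCC(=S)N1CCCC1`: 29.7%

In a functional assay on the whole organism (stomach) for inhibition, with Rattus norvegicus as the target, at a dose of 100 mg/kg by the intraduodenal route (on this read-out lower numbers stand for less inhibition and higher numbers for more inhibition at the one dose given (going by the name of the read-out)), compound 1 gives 10.1%, the lowest of the three numbers. Its nearest neighbour on this read-out is compound 3, whose number lies beyond the scatter above it; compound 2 lies furthest away, also beyond the scatter. Within the data shown here, no pair of these three compounds differs in only one place, so no step between measured compounds can be named; what their values show is that the two compounds carrying a thiocarboxamide-type group on the chain sit above the one carrying a nitrile.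

Compound 4, `CC(Cn1nc(-c2ccccc2)ccc1=O)C(=N)S`, has not been measured in this assay. It differs from compound 1 as follows: a group of 5 heavy atoms (3 carbon, 1 nitrogen, 1 sulfur; no ring) in place of a group of 3 heavy atoms (2 carbon, 1 nitrogen; no ring), on a saturated chain carbon bound to an aromatic nitrogen

Given that compound 2 with 58.5% and compound 3 with 29.7% both stand above compound 1, the step from compound 1 to compound 4 is expected to be upward and beyond the scatter, though its size is uncertain since no single-change step is available. The expected step is a number 24.9 percentage points higher from compound 1 to compound 4 (beyond the scatter). Compound 4 is therefore estimated at 35%, within a range from 12% to 60%.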

Compound 4, a percentage reported as inhibition, in the whole organism at one dose (the size of the read-out at that dose, not a potency): 86.4%
Beside the measured number, compound 4's estimate is 51.4 percentage points below it, outside the stated range (above it).
By their numbers in this assay, from the lowest: compound 1; then compound 3; then compound 2; then compound 4.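

This is the first change in one place among the compounds shown: on the shared core, cyanomethyl leaves and a group of 5 heavy atoms enters, on a saturated chain carbon bound to an aromatic nitrogen, and in this assay the number moves a number 76.3 percentage points higher from compound 1 to compound 4 (beyond the scatter). The earlier compounds shown here could only hint that this position matters, whereas this pair shows directly that changing the group there, with the core held constant, gives a large step beyond the scatter at the one dose given. The change replaces a triple bond with a double bond, brings in sulfur and goes from 0 to 2 hydrogen-bond donors, but nothing shown here explains why the number rises.

Among these compounds, the single step cannot separate the contribution of the added carbon from that of the sulfur-bearing end of the group, and, as a reading at one dose, it gives no potency. As far as these compounds go, how a carboxylic acid, an amine or a longer chain at this same place on the core of compound 1 would read in this assay remains open.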